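The compounds below may be only part of what the source reports. "The series", "measured", "known", "first", "only" and "open" are said of these compounds alone.

Measured compounds:
- compound 1, `Cc1cc(NC(=O)Nc2cc(F)ccc2F)c2ccccc2n1`: 500 nM
- compound 2, `Cc1cc(NC(=O)Nc2ccccc2C(F)(F)F)c2ccccc2n1`: 3800 nM
- compound 3, `CCc1ccc(NC(=O)Nc2cc(C)nc3ccccc23)cc1`: 3300 nM

In a physicochemical assay for solubility, at pH 7.4 (on this read-out higher numbers stand for higher solubility and lower numbers for lower solubility), compound 1 gives 500 nM, the lowest of the three numbers. Compound 3 gives 3300 nM and compound 2 gives 3800 nM; both of these stand above compound 1 by more than the scatter, while compound 2 and compound 3 lie within the scatter of each other. Going by the values given here, no pair among the measured compounds differs in only one place, so no single step has been measured.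

Compound 4, `Cc1cc(NC(=O)Nc2cccc(F)c2)c2ccccc2n1`, differs from compound 1 in one place: hydrogen in place of fluoro on an aromatic carbon. Only the fluoro group that stands ortho to the large group leaves; the fluoro group para to it stays.

Among the compounds with values here, there is no measured step of this kind to lean on. The change is small in size, a single heavy atom, and such a change would be expected to move this assay only modestly. Compound 4 is therefore expected to come close to compound 1, with a small step upward estimated, a 1.8-fold higher number from compound 1 to compound 4 (0.26 log units; within the scatter), that may well stay within the scatter. Compound 4 is estimated at 900 nM, between 300 nM and 2700 nM.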

Compound 4, solubility: 100 nM
Beside the measured number, compound 4's estimate is 9.0-fold (0.95 log units) above it; the measured number lies below the stated range.
By their numbers in this assay, from the lowest: compound 4; then compound 1; then compounds 3 and 2 (each within the scatter of the next).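

Going by these compounds alone, this is the first single step that can be read in this assay: hydrogen in place of fluoro on an aromatic carbon, ortho to a large group and para to a fluoro group, gives a 5.0-fold lower number from compound 1 to compound 4 (0.70 log units; beyond the scatter). The step lies beyond the scatter, so at this position the loss of one fluorine, with the rest of compound 1 unchanged, is enough to lower the number clearly. Nothing available explains the direction or the size of this step.

The compounds shown leave open where other groups at this position, such as chloro, methoxy or an amine, would fall in this assay relative to fluoro and hydrogen. They also leave open whether taking away the remaining fluoro group would give a step of similar size or direction.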